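The compounds below may be only part of what the source reports. "The series", "measured", "known", "first", "only" and "open" are said of these compounds alone.

Compound 1 `COc1nc2ccc(Br)cc2cc1C(c1ccccc1)n1cc(-c2ccccc2)nn1` stands highest of the two numbers measured in an ADME assay on PANC-1 cells (Homo sapiens) for cytotoxicity, read by sulforhodamine B assay, with a stated time of 48 h, tested at 10 uM (a higher number here means more inhibition at the concentration tested (going by the name of the read-out), a lower number less inhibition), giving 30.1%. Compound 2 `CCCc1cn(C(c2ccccc2)c2cc3cc(Br)ccc3nc2OC)nn1` gives 11.3% in this assay, and the step of a number 18.8 percentage points lower from compound 1 to compound 2 (beyond the scatter) lies beyond the scatter: propyl in place of phenyl on an aromatic carbon lowered inhibition by a modest amount.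

Compound 3 `COc1nc2ccc(Br)cc2cc1C(c1ccccc1)n1cc(C2CC2)nn1` differs from compound 1 by cyclopropyl in place of phenyl on an aromatic carbon. For the measured compounds named here, the only measured step that bears on this change is a number 18.8 percentage points lower from compound 1 to compound 2 (beyond the scatter), where a non-aromatic carbon group also took the place of the phenyl on the same aromatic carbon. A cyclopropyl entering that place is therefore expected to cost inhibition in this assay as well, in the same direction and of roughly similar modest size, with a step of about a number 15.1 percentage points lower from compound 1 to compound 3 (beyond the scatter) expected. Compound 3 is accordingly estimated at 15% in this assay, with a range from 4% to 30%.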

Compound 3, a percentage reported as inhibition, at one concentration (the size of the read-out at that concentration, not a potency): 21.8%
The estimate for compound 3 lay 6.8 percentage points below the measured number; the range from low to high includes it.
By their numbers in this assay, from the lowest: compound 2; then compounds 3 and 1 (each within the scatter of the next).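

In this assay, the change to cyclopropyl at this place gives a number 8.3 percentage points lower from compound 1 to compound 3 (within the scatter), so an aromatic phenyl is not needed to hold the read-out within the scatter of compound 1. The change from propyl to cyclopropyl gives a number 10.5 percentage points higher from compound 2 to compound 3 (beyond the scatter), which shows that the lower number of compound 2 does not follow simply from a non-aromatic carbon group replacing phenyl, since the two non-aromatic groups are separated beyond the scatter. Nothing available gives a cause for either step.

As far as these compounds go, whether the ring form of cyclopropyl is what separates it from propyl remains open, and a cyclohexyl ring or a longer chain such as butyl would bear on that. Also open, from the compounds shown here alone, is how an amine or a carboxylic acid at this place would read in this assay.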